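From Propoxy to 3-Nitrophenoxy: An Open Question

The source may report more compounds than this note shows. Statements on the series, on what has been measured and on what is new or still open speak of the compounds shown alone.

compound 1 `CCCOc1ccc([C@@H]2CC(=O)c3cc(CC=C(C)C)c(OC)cc3O2)cc1`: 54%
compound 2 `COc1ccc([C@@H]2C/C(=N/OCc3cn(-c4ccc(Cl)cc4C)nn3)c3cc(CC=C(C)C)c(OC)cc3O2)cc1`: 49%

Both values come from a functional assay on PC-3 cells (Homo sapiens) for inhibition, read by sulforhodamine B assay, with a stated time of 48 h, tested at 50 uM; on this read-out higher numbers stand for more inhibition of growth at the one concentration tested and lower numbers for less inhibition of growth. There, compound 1 gives 54% and compound 2 gives 49%, so compound 1 stands level with compound 2 within the usual scatter. For the measured compounds named here, the two compounds differ in more than one place, so they offer no single-change step as a guide.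

Still unmeasured is compound 3 `COc1cc2c(cc1CC=C(C)C)C(=O)C[C@@H](c1ccc(Oc3cccc([N+](=O)[O-])c3)cc1)O2`, which keeps the core of compound 1 and changes one group: 3-nitrophenyl in place of propyl on an oxygen on an aromatic ring. Here, 3-nitrophenyl takes the place of propyl on an oxygen on an aromatic ring, turning propoxy into 3-nitrophenoxy. Going by the values given here, no measured pair shows what this change does, so the expectation rests on compound 1 at 54%. No step beyond the scatter is expected in this assay, in either direction, although the uncertainty is wide. The estimated step is a number 2 percentage points lower from compound 1 to compound 3 (within the scatter). The estimated value for compound 3 is 52%, with an expected range from 35% to 68%.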

Compound 3, percent growth inhibition at one concentration: 21%
Compound 3: the middle estimate sits 31 percentage points above what was measured; the measured number lies below the stated range.
By their numbers in this assay, from the lowest: compound 3; then compounds 2 and 1 (each within the scatter of the next).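

With propyl on an oxygen on an aromatic ring replaced by 3-nitrophenyl, this assay records a number 33 percentage points lower from compound 1 to compound 3 (beyond the scatter). For the compounds shown here, this is the first single-change step, and it shows that growth inhibition at the one concentration tested depends on the group at this position, which the earlier pair, differing in more than one place, could not show. No measurement presented here bears on why this change lowers the number, so the step stands as an observation without an explanation.

The change from propoxy to 3-nitrophenoxy brings in a six-membered aromatic ring and a nitro group together, so the compounds shown cannot say how much of the step belongs to either one, a question that a plain phenyl on the same oxygen would address. They also leave open how a longer chain such as butyl, or a chain ending in an amine, would read at this position, and whether the step between these two compounds would hold at concentrations other than the single one tested.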